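The source may report more compounds than this note shows. Statements on the series, on what has been measured and on what is new or still open speak of the compounds shown alone.

Compound 1 `CCCCc1ccc(Nc2nc(CC(=O)O)cs2)cc1`: 3.1 h
Compound 2 `CCCCc1ccc(Nc2nc(C(C)(C)C(=O)O)cs2)cc1`: 5 h
Compound 3 `CCCCc1ccc(Nc2nc(CC(=O)O)c(C)s2)cc1`: 1.1 h

In an ADME assay on the whole organism for metabolic stability, with Mus musculus as the target (on this read-out higher numbers stand for a longer-lived compound and lower numbers for a shorter-lived compound), compound 1 gives 3.1 h. That is second highest of the three numbers, though its gap to compound 2 lies within the scatter, while compound 3 stands clearly lower. Compound 4 `CCC(C)c1ccc(Nc2nc(CC(=O)O)cs2)cc1` has not been measured. It carries one change: sec-butyl in place of butyl on an aromatic carbon. It has sec-butyl in place of butyl on an aromatic carbon, with the same atoms joined differently. Going by the values given here, no measured step alters the butyl chain, so the two available steps offer only a sense of size: a 1.6-fold higher number from compound 1 to compound 2 (0.21 log units; within the scatter), and a 2.8-fold lower number from compound 1 to compound 3 (0.45 log units; beyond the scatter). With no direct evidence for a shift, no change beyond the scatter is expected, and the expected step is a 1.0-fold lower number from compound 1 to compound 4 (0.01 log units; within the scatter). For compound 4, the estimated half-life is 3 h, with an expected range of 1.3 h to 6.5 h.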

Compound 4, half-life: 2.8 h
For compound 4 the middle estimate is 1.1-fold (0.03 log units) above the measured one, and the stated range covers the measured number.
By their numbers in this assay, from the lowest: compound 3; then compounds 4, 1 and 2 (each within the scatter of the next).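

Putting sec-butyl in place of butyl in this assay gives a 1.1-fold lower number from compound 1 to compound 4 (0.04 log units; within the scatter). Going by these compounds alone, this is the first view of the chain on the aromatic carbon para to a large group, and here joining the same atoms differently leaves no change that can be told from the scatter. Nothing measured here bears on the reason for this result.

Only one rearrangement of this chain is shown, so a single result cannot say how far this position tolerates change. A tert-butyl group, a longer chain, a cyclohexyl ring or an amine here could behave differently.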